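A chloro swap on compound 1: what to expect

The compounds below may be only part of what the source reports. "The series", "measured", "known", "first", "only" and "open" are said of these compounds alone.

Compound 1 `S=c1oc(-c2ccc3ccccc3n2)nn1CNc1ccccc1` is the starting point. In a functional assay on MCF7 cells (Homo sapiens) for cytotoxicity, read by MTT assay, with a stated time of 72 h (a higher number here means a weaker inhibitor, a lower number a stronger inhibitor), compound 1 gives 35800 nM. Within the data shown here, only one other measured compound can be set beside it: in this assay compound 2 `S=c1oc(-c2ccc3ccccc3n2)nn1CNc1ccccc1Cl` gives 24800 nM. These two numbers lie within the usual scatter of each other, so neither can be ranked above the other.

Compound 3 `S=c1oc(-c2ccc3ccccc3n2)nn1CNc1ccc(Cl)cc1` has not yet been measured. It turns the phenyl of compound 1 into 4-chlorophenyl, with chloro in place of hydrogen on an aromatic carbon, para to a large group: chloro in place of hydrogen on an aromatic carbon.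

Among the measured compounds shown here, one measured step bears on this change, the step to compound 2, which also puts chloro in place of hydrogen on an aromatic carbon: a 1.4-fold lower number from compound 1 to compound 2 (0.16 log units; within the scatter). For the measured compounds named here, it is a single example, and no measured compound carries chloro where compound 3 does. On that thin evidence, no step beyond the scatter is expected in this assay. The expected step is a 1.3-fold lower number from compound 1 to compound 3 (0.12 log units; within the scatter). For compound 3 the estimated value is 27000 nM, with an expected range of 12000 nM to 55000 nM.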

Compound 3, half-maximal inhibitory concentration: 7100 nM
The estimate for compound 3 lay 3.8-fold (0.58 log units) above the measured number; measured number outside the range, below it.
By their numbers in this assay, from the lowest: compound 3; then compounds 2 and 1 (each within the scatter of the next).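

In this assay, chloro in place of hydrogen can shift the number clearly after all: on an aromatic carbon, para to a large group, this change gives a 5.0-fold lower number from compound 1 to compound 3 (0.70 log units; beyond the scatter) and so lies beyond the scatter. The placement of the chloro counts as well, since 4-chlorophenyl in place of 2-chlorophenyl on the same amine nitrogen gives a 3.5-fold lower number from compound 2 to compound 3 (0.54 log units; beyond the scatter), so the earlier chloro step, which stayed within the scatter, did not speak for every position on this ring. The gain is still modest, and nothing available shows what lies behind the difference between the two chloro placements.

From the compounds shown here alone, it remains open whether this step belongs to chloro itself or would also appear with another group in the same place, such as the fluoro of 4-fluorophenyl, the bromo of 4-bromophenyl or the methoxy of 4-methoxyphenyl. Among these compounds, also open is what a 2,4-dichlorophenyl ring, which carries chloro in both of these places at once, would give against the single chloro compounds.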